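Cyanine dyes tested for binding to an arginine methyltransferase

The compounds below may be only part of what the source reports. "The series", "measured", "known", "first", "only" and "open" are said of these compounds alone.

Compound 1 `CCCC[N+]1=C(/C=C/C=C2/N(C)c3ccccc3C2(C)C)C(C)(C)c2ccccc21` — 8%
Compound 2 `CCCCN1/C(=C/C(/C=C/c2ccccc2)=C/c2sc3ccccc3[n+]2CCCC)Sc2ccccc21` — 48%
Compound 3 `CC1=[N+](CCCc2ccccc2)c2ccccc2C1(C)C` — "not active" (no number reported), no number given

In an assay for displacement of a labelled ligand from protein arginine N-methyltransferase 1 (Homo sapiens), read by scintillation proximity assay, with stated times of 5 min and 8 min, tested at 10 uM (on this read-out lower numbers stand for a weaker effect and higher numbers for a stronger effect at the one concentration tested), compound 1 gives 8%. Compound 2 gives 48%, a number well beyond the scatter above that of compound 1. Compound 3, which carries a 3-phenylpropyl group on its ring nitrogen, gives "not active" (no number reported), without a number. Among the measured compounds shown here, compound 1 thus stands lowest of the two compounds for which a number is given, and no step between measured compounds that differ in one place is available.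

Compound 4 `CN1/C(=C/C=C/C2=[N+](CCCc3ccccc3)c3ccccc3C2(C)C)C(C)(C)c2ccccc21` is the not yet measured compound. It differs from compound 1 in one place: phenyl in place of methyl on a saturated chain carbon, three bonds along the chain from a double-bonded nitrogen in a ring. For the measured compounds named here, no measured pair shows this change directly, so the size of the step can only be expected. Because compound 3, which carries the same group, gives "not active" (no number reported), and because compound 1 gives 8%, the step from compound 1 to compound 4 is expected to be small, a number 4 percentage points higher from compound 1 to compound 4 (within the scatter), and to lie within the scatter in either direction. Compound 4 is therefore estimated at 12%, with a range from 0% to 30%.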

Compound 4, a percentage reported as inhibition, at one concentration (the size of the read-out at that concentration, not a potency): 35%
For compound 4 the middle estimate is 23 percentage points below the measured one, and the stated range ends below it.
By their numbers in this assay, from the lowest: compound 1; then compound 4; then compound 2.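

In this assay, the exchange of methyl for phenyl at the end of the chain, which turns butyl into 3-phenylpropyl, gives a number 27 percentage points higher from compound 1 to compound 4 (beyond the scatter), so the read-out at this position responds to the change and the larger group is tolerated. Among the compounds shown here, the earlier compounds held no pair that differed in one place, which makes this the first step that can be read on the shared core, and it shows that the chain position is not a silent one in this assay. Since the result comes from a single concentration, it describes the size of the read-out and not a potency, and nothing measured here accounts for the step.

On these data alone, whether the gain depends on the length of the chain remains open, since benzyl and phenethyl would separate the phenyl ring's presence from its distance along the chain, and an amine or a carboxylic acid at the chain end would show whether phenyl itself is needed. Also open, as far as these compounds go, is whether a second 3-phenylpropyl group, in place of the remaining methyl on the other nitrogen of the core, would add to this step or leave the read-out where it stands.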